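A few compounds are considered here, and "the series" means these few. Any claim that something is new, unique, unknown or untested is made for them only; others in the source may bear on it.

Measured so far in a physicochemical assay for lipophilicity, read by HPLC, at pH 7.5; a higher number here means a more lipophilic compound, a lower number a more polar compound

compound 1 `N#Cc1c(-c2ccc(Br)cc2)nc2cnccc2c1NCC(N)=O` gives 1.9
compound 2 `CCOc1ccccc1-c1ccc(-c2nc3cnccc3c(C[C@H](C)C(=O)O)c2C#N)cc1` gives 2.2

Compound 1 and compound 2 lie within the usual scatter of each other, so these two values set no order between them. For the measured compounds named here, compound 1 therefore stands level with the only other number available, and the two structures differ in more than one place.

The next compound is compound 3 `CN(CC(N)=O)c1c(C#N)c(-c2ccc(Br)cc2)nc2cnccc12` which has not yet been measured. Its change from compound 1 is methyl in place of hydrogen on a nitrogen on an aromatic ring and in words this is methyl in place of hydrogen on a nitrogen on an aromatic ring, so that (carbamoylmethyl)amino becomes (carbamoylmethyl)(methyl)amino.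

Going by the values given here, no pair of measured compounds shows this change. The expectation therefore rests on the structural change alone, with compound 1 at 1.9 as the starting point. A small rise is expected for the step of a number 0.30 log units higher from compound 1 to compound 3 (within the scatter) in this assay and it may not clear the scatter. Compound 3 is estimated at 2.2 with an expected range from 1.8 to 2.6 around that figure.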

Compound 3, distribution coefficient: 2.1
Estimate against measurement, compound 3: 0.10 log units above; the range from low to high includes it.
By their numbers in this assay, from the lowest: compounds 1, 3 and 2 (each within the scatter of the next).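

In this assay, methyl in place of hydrogen on the nitrogen gives a number 0.20 log units higher from compound 1 to compound 3 (within the scatter), so compound 1 and compound 3 stand level in this read-out. For the compounds shown here, this is the first comparison that differs in one place, which compound 2 could not provide, since its structure differs from compound 1 in more than one place. At this position, in the core of compound 1 and with the 4-bromophenyl-bearing structure unchanged, going from (carbamoylmethyl)amino to (carbamoylmethyl)(methyl)amino leaves the number within the scatter, although a single pair cannot establish a trend. No measurement is available that bears on the origin of this result.

The compounds shown leave open whether a longer chain on this nitrogen, such as ethyl or propyl, would give a step that clears the scatter. They also leave open how this nitrogen substituent would read with a carboxylic acid or an amine in place of the carbamoyl group, and whether methyl gives a comparable step on a structure closer to compound 2.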